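The source may hold more compounds than are shown below. What is called first, only, known or untested is meant among the compounds shown, and "the series" means these compounds.

Measured compounds, values in a functional assay on MKN-74 cells (Homo sapiens) for antiproliferative activity, with a stated time of 24 h; a higher number here means a weaker inhibitor, a lower number a stronger inhibitor:
Compound 1 `Cc1ccccc1CN1CCc2c(sc(NC(=O)c3ccccc3Cl)c2C(N)=O)C1` gives > 50000 nM, which is a limit of the assay.
Compound 2 `NC(=O)c1c(NC(=O)c2ccccc2Cl)sc2c1CCN(Cc1ccc(Cl)cc1Cl)C2` gives 16300 nM.
Compound 3 `NC(=O)c1c(NC(=O)c2ccccc2Cl)sc2c1CCN(C(=S)Nc1cccc3ccccc13)C2` gives 20700 nM.

Compound 3 holds the highest of the two numbers; its nearest neighbour is compound 2, and the gap between them lies within the scatter. Compound 4 `CSc1ccccc1NC(=S)N1CCc2c(sc(NC(=O)c3ccccc3Cl)c2C(N)=O)C1` differs from compound 3 in one place: 2-(methylsulfanyl)phenyl in place of naphthalen-1-yl on an amide-type nitrogen. Among the measured compounds shown here, the only measured step, an at least 3.0-fold lower number from compound 1 to compound 2 (0.48 log units; beyond the scatter), concerns the saturated chain carbon bound to the amine nitrogen in the ring, not the amide-type nitrogen changed here, so it does not bear on this change. Compound 1 sits at the limit of > 50000 nM in this assay, at which 1 of the 3 values shown sits. For the measured compounds named here, with no measured step at this position, no shift beyond the scatter is expected, and compound 4 is estimated at 20000 nM (range 8000 nM to 50000 nM). That corresponds to an expected 1.0-fold lower number from compound 3 to compound 4 (0.01 log units; within the scatter).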

Compound 4, half-maximal inhibitory concentration: 13800 nM
Beside the measured number, compound 4's estimate is 1.4-fold (0.16 log units) above it, within the range that was stated.
By their numbers in this assay, from the lowest: compounds 4, 2 and 3 (each within the scatter of the next). At a limit, above all of these: compound 1.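

In this assay, the change on the amide-type nitrogen gives a 1.5-fold lower number from compound 3 to compound 4 (0.18 log units; within the scatter), so replacing naphthalen-1-yl with 2-(methylsulfanyl)phenyl, with one aromatic ring fewer, leaves the read-out unresolved from that of compound 3. On the amine nitrogen in the ring, the larger group gives a 1.2-fold lower number from compound 2 to compound 4 (0.07 log units; within the scatter), again with no separation. The remaining step, an at least 3.6-fold lower number from compound 1 to compound 4 (0.55 log units; beyond the scatter), gives only a bound because compound 1 stands at a limit: the limit of > 50000 nM in this assay, at which 1 of the 4 values shown sits.

Open, as far as these compounds go, is whether a simple alkyl chain or a carboxylic acid on the amide-type nitrogen would shift the read-out beyond the scatter. The role of the methylsulfanyl group itself also stays unresolved, as no phenyl partner without it is shown.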